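A methoxy added to an inactive pyrazoline pair

The compounds below may be only part of what the source reports. "The series", "measured", "known", "first", "only" and "open" are said of these compounds alone.

Compound 1, `CC(=O)N1N=C(c2ccc(OCc3cn(Cc4ccc([N+](=O)[O-])cc4)nn3)cc2)CC1c1ccccc1`, was tested in a functional assay on THP-1 cells (Homo sapiens) for inhibition, read by sulforhodamine B assay, tested at 10 uM (on this read-out higher numbers stand for more inhibition of growth at the one concentration tested and lower numbers for less inhibition of growth), and gave 0%. Compound 2, `COc1cc(C2CC(c3ccc(OCc4cn(Cc5ccc([N+](=O)[O-])cc5)nn4)cc3)=NN2C(C)=O)ccc1Oc1cn(Cc2ccc([N+](=O)[O-])cc2)nn1`, carries a second triazole-linked ether and in this assay compound 2 gave 0%. The two values are level with each other, so the larger addition in compound 2 brought nothing that could be seen beyond the usual scatter.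

Compound 3, `COc1ccc(C2CC(c3ccc(OCc4cn(Cc5ccc([N+](=O)[O-])cc5)nn4)cc3)=NN2C(C)=O)cc1`, has not yet been measured. It differs from compound 1 in one place only: methoxy in place of hydrogen on an aromatic carbon. Both measured compounds show no growth inhibition in this assay, and a small group of two heavy atoms on a ring that is otherwise unchanged gives no reason from these data to expect a different picture. The step from compound 1 to compound 3 is expected to be a number 2 percentage points higher from compound 1 to compound 3 (within the scatter), that is, none beyond the scatter. In this assay compound 3 is therefore estimated at 2%, within a range from -8% to 12%.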

Compound 3, percent growth inhibition at one concentration: 15%
Beside the measured number, compound 3's estimate is 13 percentage points below it, outside the stated range (above it).
By their numbers in this assay, from the lowest: compounds 1 and 2 (each within the scatter of the next); then compound 3.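

In this assay, putting methoxy in place of hydrogen on this aromatic carbon, para to a large group, gives a number 15 percentage points higher from compound 1 to compound 3 (beyond the scatter) and so takes the read-out past the usual scatter. Going by these compounds alone, this is the first step between compounds differing in one place, and it shows that this position on the ring is not silent: even a small group placed here can change growth inhibition. Nothing measured here speaks to the cause of this rise.

On these data alone, it remains open whether the gain belongs to methoxy itself or would also appear with another group on the same carbon, such as a hydroxyl, a fluorine atom, an amine or a longer ether chain. A single step at one concentration also cannot show how far growth inhibition can rise through changes at this position.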